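The compounds below may be only part of what the source reports. "The series", "measured", "known", "first", "only" and "open" are said of these compounds alone.

Going by the values given here, compound 2 `Cc1nc(Nc2ccccc2)nc(N[C@@H]2C[C@H](CO)[C@@H](O)[C@H]2O)c1-c1nc2cnccc2s1` is one of two compounds measured in an ADME assay on cells (Homo sapiens) for cytotoxicity, read by polymerase chain reaction, with a stated time of 3 days; on this read-out lower numbers stand for higher toxicity in this test and higher numbers for lower toxicity in this test. In this assay compound 2 gives 25000 nM. Among the compounds with values here, its only measured neighbour is compound 1 `Cc1nc(NC2CC2)nc(N[C@@H]2C[C@H](CO)[C@@H](O)[C@H]2O)c1-c1nc2cnccc2s1`, which carries cyclopropyl in place of the phenyl; in this assay compound 1 gives 25000 nM. Within the data shown here, the one measured step, no change at the digits printed from compound 1 to compound 2 (within the scatter), shows that swapping the group on that nitrogen left the read-out where it was, so compound 2 stands level with compound 1 on the numbers available.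

Compound 3 `Cc1ccc([C@@H](C)Nc2nc(C)c(-c3nc4cnccc4s3)c(N[C@@H]3C[C@H](CO)[C@@H](O)[C@H]3O)n2)cc1` has not yet been measured. Among the measured compounds shown here, its single difference from compound 2 is 1-(4-methylphenyl)ethyl in place of phenyl on a nitrogen on an aromatic ring. For the measured compounds named here, the only step that bears on this change is the one from compound 1 to compound 2, which also exchanged the group on this same nitrogen and moved nothing beyond the scatter. Going by the values given here, with that as the sole guide, the step of no change at the digits printed from compound 2 to compound 3 (within the scatter) is expected to be none beyond the scatter. Compound 3 is therefore estimated at 25000 nM, with a range from 12000 nM to 50000 nM.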

Compound 3, half-maximal cytotoxic concentration: 25000 nM
Estimate against measurement, compound 3: no gap at the digits printed; the range from low to high includes it.
By their numbers in this assay, from the lowest: compounds 1, 2 and 3 (each within the scatter of the next).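

In this assay, 1-(4-methylphenyl)ethyl brings 9 heavy atoms and 1 defined stereocentre to the nitrogen on an aromatic ring, where phenyl has 6 heavy atoms and no defined stereocentre, yet the result is no change at the digits printed from compound 2 to compound 3 (within the scatter). Set against the cyclopropyl group, the same exchange gives no change at the digits printed from compound 1 to compound 3 (within the scatter), so three different carbon-only groups now stand on this nitrogen with no movement in the read-out, where the earlier pair offered only a single exchange. Nothing available explains why the read-out stays put across these groups.

The compounds shown leave open whether this flat picture holds once the group on this nitrogen contains atoms other than carbon, such as an amine, a carboxylic acid or a longer chain ending in a hydroxyl group. They also leave open whether the mirror-image form of the 1-(4-methylphenyl)ethyl group, with its one stereocentre reversed, would read the same in this assay, and whether changes elsewhere on the shared core would move this read-out.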